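Removing a methyl from a ring-bound nitrogen

The source may hold more compounds than are shown below. What is called first, only, known or untested is meant among the compounds shown, and "the series" means these compounds.

Compound 1 `CN(CCC(=O)N1CCCC1)c1nc2cc(Cl)ccc2o1` carries a methyl on a nitrogen attached to its aromatic core, and the nitrogen links onward to a short chain ending in a pyrrolidine amide. In an ADME assay on microsomes from liver (Mus musculus) for metabolic stability, read by LC-MS, using NADPH, with a stated time of 45 min, tested at 0.5 uM (on this read-out higher numbers stand for fast clearance and lower numbers for slow clearance), compound 1 is recorded as "not determined" (no result reported), so its own standing cannot be read from a value. Two related compounds do have numbers. Compound 2 `CN(C(=O)CCSc1nc2cc(Cl)ccc2o1)C1CCS(=O)(=O)C1` gives 0.8 mL/min/g in this assay, and compound 3 `CN(C(=O)CCSc1nc2cc(F)ccc2o1)C1CCS(=O)(=O)CC1` gives 0.6 mL/min/g; these two values sit within the usual scatter of each other, so nothing separates them. For the measured compounds named here, both differ from compound 1 in several places at once, so no single step between measured compounds can be followed.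

Compound 4 `O=C(CCNc1nc2cc(Cl)ccc2o1)N1CCCC1` is compound 1 with one change: hydrogen in place of methyl on a nitrogen on an aromatic ring. Going by the values given here, no measured pair isolates this change, so the size and direction of its effect in this assay are open; an effect within the usual scatter, or none, is as plausible as a shift either way.

On that basis, and with compound 2 and compound 3 as the only anchors, compound 4 is expected to give about 1 mL/min/g in this assay, with a likely range from 0.4 mL/min/g to 2.5 mL/min/g.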

Compound 4, intrinsic clearance in a liver preparation (reported as CLH), per the amount of preparation that the assay uses: 81.1 mL/min/g
Estimate against measurement, compound 4: 81-fold (1.91 log units) below; the whole stated range lies below it.
By their numbers in this assay, from the lowest: compounds 3 and 2 (each within the scatter of the next); then compound 4.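

No step can be read from this result: compound 1, which differs from compound 4 in one place, has no single number in this assay, and compound 2 and compound 3 differ from compound 4 in several places. Nothing shown here offers an explanation for the value of compound 4. On these data alone, what hydrogen in place of methyl on that nitrogen does to clearance, in size or direction, stays open.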